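Chain lengthening on the core of compound 3

The source may report more compounds than this note shows. Statements on the series, on what has been measured and on what is new or still open speak of the compounds shown alone.

Measured so far in a functional assay on the whole organism (Abdomen, strain Swiss) for inhibition, with Mus musculus as the target, with stated times of 30 min, 10 min and 5 min, at a dose of 10 mg/kg by the oral route; a higher number here means a stronger effect of the compound at the dose given, a lower number a weaker effect:
Compound 1, `CCc1nn(CCCN2CCN(c3ccc(C)cc3)CC2)c(=O)c(N)c1C(C)=O`, gives 10%.
Compound 2, `CC(=O)c1c(C)nn(CCCN2CCN(c3ccc(C)cc3)CC2)c(=O)c1N`, gives 19%.
Compound 3, `C=Cc1c(CC)nn(CCCN2CCN(c3ccc(C)cc3)CC2)c(=O)c1N`, gives 0%.

Compound 3 stands lowest of the three numbers, though compound 1 lies within the scatter of it; only compound 2 lies beyond. Compound 4, `C=Cc1c(CCC)nn(CCCN2CCN(c3ccc(C)cc3)CC2)c(=O)c1N`, differs from compound 3 by methyl in place of hydrogen on a saturated chain carbon, two bonds along the chain from an aromatic carbon. Among the compounds with values here, the one measured step that touches this chain, a number 9 percentage points higher from compound 1 to compound 2 (within the scatter), runs the opposite way one bond nearer the ring and stays within the scatter; the other, a number 10 percentage points lower from compound 1 to compound 3 (within the scatter), concerns a different group. On that basis no step beyond the scatter is expected in this assay from compound 3 to compound 4, so compound 4 is estimated at 3%, in the range 0% to 15%, an expected step of a number 3 percentage points higher from compound 3 to compound 4 (within the scatter).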

Compound 4, a percentage reported as inhibition, in the whole organism at one dose (the size of the read-out at that dose, not a potency): 3%
Beside the measured number, compound 4's estimate shows no gap at the digits printed; low and high end bracket the measured number.
By their numbers in this assay, from the lowest: compounds 3, 4, 1 and 2 (each within the scatter of the next, the first and the last beyond it).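

In this assay, exchanging hydrogen for methyl on a saturated chain carbon, two bonds along the chain from an aromatic carbon, turns ethyl into propyl on a core carrying vinyl and gives a number 3 percentage points higher from compound 3 to compound 4 (within the scatter). The earlier compounds had shown this kind of change only with acetyl on the core. The two readings cannot be told apart: the same change on two cores in this assay, a number 9 percentage points higher (within the scatter) from compound 1 to compound 2 and a number 3 percentage points lower (within the scatter) from compound 4 to compound 3, 12 percentage points apart, within the scatter of two such steps

From the compounds shown here alone, whether a butyl chain, or an amine or carboxylic acid at the end of this chain, would move the number beyond the scatter stays open. The compounds shown also leave open how this chain behaves at any other dose.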